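The compounds below may be only part of what the source reports. "The series", "measured", "known", "first", "only" and "open" are said of these compounds alone.

Compound 1, `O=S(=O)(c1cc(Cl)cc(Cl)c1)c1cnc2c(F)cccc2c1-c1ccc(F)cc1`, and compound 2, `O=S(=O)(c1cc(Cl)cc(Cl)c1)c1cnc2c(F)cccc2c1-c1ccc(Cl)cc1`, share a core and differ only in one spot: chloro in place of fluoro on an aromatic carbon. In an ADME assay on microsomes from liver (Homo sapiens) for metabolic stability, tested at 2.5 uM (a lower number here means slower removal, a higher number faster removal of the compound), compound 1 gives 1.01 mL/min, and compound 2 gives 0.78 mL/min, so the step of a 1.3-fold lower number from compound 1 to compound 2 (0.11 log units; within the scatter) is small. Compound 3, `Cc1ccc(S(=O)(=O)c2cnc3c(F)cccc3c2-c2cccc(F)c2)cc1F`, is built on a different core, and the difference between the two cores is not broken down here. In this assay compound 3 gives 3.92 mL/min, the highest of the three numbers. Compound 4, `Cc1ccc(S(=O)(=O)c2cnc3c(F)cccc3c2-c2cccc(Cl)c2)cc1F`, is compound 3 with chloro in place of fluoro on an aromatic carbon; this is the same kind of change as from compound 1 to compound 2, but not the same. There the chloro sits para to a large group; here it sits meta to a large group. For compound 4 the step of a 1.3-fold lower number from compound 3 to compound 4 (0.12 log units; within the scatter) is expected to resemble a 1.3-fold lower number from compound 1 to compound 2 (0.11 log units; within the scatter), because that step is within the scatter. Compound 4 is therefore estimated at 3 mL/min, between 1.5 mL/min and 6 mL/min.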

Compound 4, intrinsic clearance in a liver preparation (reported as CLH), per the amount of preparation that the assay uses: 3.18 mL/min
Beside the measured number, compound 4's estimate is 1.1-fold (0.03 log units) below it; the range from low to high includes it.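

In this assay the step of a 1.2-fold lower number from compound 3 to compound 4 (0.09 log units; within the scatter) is small, and chloro in place of fluoro behaves alike on the two cores: the same change on two cores in this assay, a 1.3-fold lower number (0.11 log units; within the scatter) from compound 1 to compound 2 and a 1.2-fold lower number (0.09 log units; within the scatter) from compound 3 to compound 4, 1.1-fold (0.02 log units) apart, within the scatter of two such steps. Within these two pairs the change therefore carries from one core to the other as a step within the scatter, and neither pair separates chloro from fluoro. This does not show that the change would stay as small on a further core, and it cannot separate the core from the position, since in compound 4 the chloro sits meta to a large group.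

The compounds shown leave open whether a group other than a halogen at this place, such as a methoxy group, an amine or a nitrile, would move the number. They also leave open what sets the two cores apart in this assay.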